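Lactam to cyclic sulfonamide on a weak triazine series

The source may report more compounds than this note shows. Statements on the series, on what has been measured and on what is new or still open speak of the compounds shown alone.

Measured compounds:
compound 1, `Cc1cc(=O)oc2cc(OCc3nc(N)nc(Nc4ccc(F)cc4)n3)ccc12`, 18300 nM
compound 2, `Cc1ccc(Nc2nc(N)nc(COc3cccc(N4CCCCC4=O)c3)n2)cc1Cl`, 22400 nM

Both compounds were characterised in an assay on COS-7 cells for agonist activity at Free fatty acid receptor 1 (Homo sapiens), read by scintillation counting and inositol phosphate accumulation, with a stated time of 90 min; a higher number here means that more compound is needed for the effect, a lower number that less compound is needed. Compound 1 gives 18300 nM and compound 2 gives 22400 nM; compound 2 holds the higher of the two numbers, but the gap to compound 1 lies within the scatter of the measurement, so the two cannot be told apart.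

Compound 3, `Cc1ccc(Nc2nc(N)nc(COc3cccc(N4CCCS4(=O)=O)c3)n2)cc1Cl`, has not yet been measured. It differs from compound 2 by a group of 7 heavy atoms (3 carbon, 1 nitrogen, 2 oxygen, 1 sulfur; one five-membered non-aromatic ring with 2 hetero atoms) in place of a group of 7 heavy atoms (5 carbon, 1 nitrogen, 1 oxygen; one six-membered non-aromatic ring with 1 hetero atom), on an aromatic carbon. Within the data shown here, no measured pair shows this kind of exchange, so there is no step to lean on. With both measured compounds sitting at similarly high numbers, the change from compound 2 to compound 3 is expected to stay within the scatter, as a 1.1-fold lower number from compound 2 to compound 3 (0.05 log units; within the scatter). Compound 3 is therefore estimated at 20000 nM in this assay, within a range from 7000 nM to 60000 nM.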

Compound 3, half-maximal effective concentration: 9700 nM
Compound 3: middle estimate off by 2.1-fold (0.31 log units), on the high side; measured number inside the range.
By their numbers in this assay, from the lowest: compounds 3, 1 and 2 (each within the scatter of the next, the first and the last beyond it).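

On the aromatic carbon meta to a large group, the ring attached through its nitrogen turns out to matter in this assay: exchanging 2-oxopiperidin-1-yl for the five-membered ring holding nitrogen and sulfur gives a 2.3-fold lower number from compound 2 to compound 3 (0.36 log units; beyond the scatter). Among these compounds, this is the first step that can be read as a change at one place, and it is modest, so the position responds to this exchange without the series leaving its weak range. No available measurement accounts for the shift.

The exchange alters ring size and replaces the carbonyl with a sulfonyl group at once, so the compounds shown do not separate the two; a five-membered lactam, pyrrolidin-2-one, or the six-membered cyclic sulfonamide would do so. On these data alone, how this position responds to an open-chain methanesulfonamide, a carboxylic acid or an amine also remains open.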